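Sulfone series: chloro for cyano on the fused core

This account rests on a few compounds, and the source may have more. Where it says the series, first, only, none or still open, it means among the compounds named here.

Measured so far in an ADME assay on microsomes from liver (Homo sapiens) for metabolic stability, tested at 2.5 uM; a higher number here means faster removal of the compound, a lower number slower removal:
- compound 1 `O=S(=O)(c1ccc(F)cc1)c1cnc2cc(F)c(Cl)cc2c1-c1ccc(Cl)cc1`: 0.01 mL/min
- compound 2 `O=S(=O)(c1cc(F)cc(F)c1)c1cnc2cc(F)ccc2c1-c1cccc(Cl)c1`: 0.22 mL/min
- compound 3 `N#Cc1ccc2ncc(S(=O)(=O)c3ccc(F)cc3)c(-c3ccc(Cl)cc3)c2c1`: 0.01 mL/min

Compound 3 stands level with compound 1 at the digits shown, and the two together give the lowest numbers of the three in this assay; compound 2 gives a higher number, a gap beyond the usual scatter. Within the data shown here, no pair of measured compounds differs in one place only, so no single-change step is available.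

Compound 4 `O=S(=O)(c1ccc(F)cc1)c1cnc2ccc(Cl)cc2c1-c1ccc(Cl)cc1` is the next candidate. It differs from compound 3 as follows: chloro in place of cyano on an aromatic carbon. Compound 1 also carries a chloro on its core and reads the same digits as compound 3 in this assay, which suggests this replacement need not move the number much. The expected step is small, either none beyond the scatter or slightly upward, about a 2.0-fold higher number from compound 3 to compound 4 (0.30 log units; within the scatter). Compound 4 is therefore estimated at 0.02 mL/min in this assay, within a range from 0.005 mL/min to 0.08 mL/min.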

Compound 4, intrinsic clearance in a liver preparation (reported as CLH), per the amount of preparation that the assay uses: 0.01 mL/min
For compound 4 the middle estimate is 2.0-fold (0.30 log units) above the measured one, within the range that was stated.
By their numbers in this assay, from the lowest: compounds 1, 3 and 4 (each within the scatter of the next); then compound 2.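

In this assay, the step at this aromatic carbon reads no change at the digits printed from compound 3 to compound 4 (within the scatter), so the measurements do not separate chloro from cyano at this place on the shared core. A second single change, hydrogen in place of fluoro on an aromatic carbon, reads no change at the digits printed from compound 1 to compound 4 (within the scatter), so the fluoro of compound 1 is likewise not separated from hydrogen in this assay. The data shown offer no explanation for either result.

Compound 2 differs from the other compounds in more than one place, so it gives no direct reading on either change. As far as these compounds go, whether an amine or a carboxylic acid on this aromatic carbon would read as chloro and cyano do here remains open.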